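Dropping the ethyl group from compound 2

The source may report more compounds than this note shows. Statements on the series, on what has been measured and on what is new or still open speak of the compounds shown alone.

Measured so far in a functional assay on MDA-MB-231 cells (Homo sapiens) for cytotoxicity, read by sulforhodamine B assay, with a stated time of 72 h (on this read-out higher numbers stand for weaker inhibition and lower numbers for stronger inhibition), each value a limit and not a number:
compound 1 `CSC(=O)c1c(O[C@@H]2O[C@H](CO)[C@@H](O)[C@H](O)[C@H]2O)c(C)c(O)c(C)c1C(C)C` gives > 40000 nM
compound 2 `CCc1c(O)c(C)c(O[C@@H]2O[C@H](CO)[C@@H](O)[C@H](O)[C@H]2O)c(C(=O)SC)c1C(C)C` gives > 40000 nM

Compound 2 stands at > 40000 nM, which is a limit of the assay and not a number. Within the data shown here, it has no measured value to separate it from compound 1, and the series so far sits at the limit of > 40000 nM in this assay, at which 2 of the 2 values shown sit.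

Compound 3 `CSC(=O)c1c(C(C)C)cc(O)c(C)c1O[C@@H]1O[C@H](CO)[C@@H](O)[C@H](O)[C@H]1O` carries hydrogen in place of ethyl on an aromatic carbon, ortho to a hydroxy group and ortho to an isopropyl group: hydrogen in place of ethyl on an aromatic carbon.

Among the measured compounds shown here, the one measured step bearing on this change is a step that the two limits leave unreadable from compound 1 to compound 2, and it offers no size to carry over. Resting on that step of compound 1 to compound 2, no step beyond the scatter is expected in this assay, and no direction can be assigned. The estimated step is a number no higher from compound 2 to compound 3 (the limit leaves the size open). Compound 3 is expected at 40000 nM, within an estimated range of 15000 nM to 80000 nM.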

Compound 3, half-maximal inhibitory concentration: > 40000 nM
Compound 3: only a limit was reported (the forecaster's own chance of this, stated with the estimate: 85%); the middle value lies on the limit itself.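

In this assay compound 3 gives > 40000 nM, a limit of the assay and not a number. No new step can be read among compound 1, compound 2 and compound 3. The compounds shown leave open whether hydrogen, methyl or ethyl on this aromatic carbon makes any difference to cytotoxicity.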